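Working notes: ethylsulfanyl in place of ethylamino

The source may report more compounds than this note shows. Statements on the series, on what has been measured and on what is new or still open speak of the compounds shown alone.

Compound 1 `CCCc1nc2cnccc2c(=O)[nH]1` gives 8.8
Compound 2 `CCNc1nc2cnccc2c(=O)[nH]1` gives 8.6

In a physicochemical assay for acid dissociation, compound 2 reads 8.6 and lies within the scatter of compound 1. Compound 3 `CCSc1nc2cnccc2c(=O)[nH]1` carries ethylsulfanyl in place of ethylamino on an aromatic carbon. For the measured compounds named here, the one measured step at this place is a number 0.20 log units lower from compound 1 to compound 2 (within the scatter) and stays within the scatter, but ethylsulfanyl does not occur in it, so it guides the new step only loosely. A modest step to a lower number is expected in this assay with wide margins. The expected step is a number 0.50 log units lower from compound 2 to compound 3 (beyond the scatter) by estimate only. For compound 3 the estimate is 8.1 with an expected range from 7.6 to 8.7 in this measurement.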

Compound 3, acid dissociation constant: 6.8
Compound 3: middle estimate off by 1.30 log units, on the high side; measured number below the stated range.
By their numbers in this assay, from the lowest: compound 3; then compounds 2 and 1 (each within the scatter of the next).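

In this assay the aromatic carbon between two ring nitrogen atoms proves sensitive to its group: ethylsulfanyl in place of ethylamino gives a number 1.80 log units lower from compound 2 to compound 3 (beyond the scatter) and ethylsulfanyl in place of propyl gives a number 2.00 log units lower from compound 1 to compound 3 (beyond the scatter) on the same core. Propyl and ethylamino alone had given no sign of this, their readings lying within the scatter of each other. No available evidence accounts for the shift.

Still open, as far as these compounds go, is whether the shift is specific to ethylsulfanyl or extends to methylsulfanyl, ethoxy or a longer sulfur-linked chain at this position.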